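The source may hold more compounds than are shown below. What is called first, only, known or untested is meant among the compounds shown, and "the series" means these compounds.

Of the compounds shown here, three have been measured in an ADME assay on NIH3T3 cells (Mus musculus) for cytotoxicity, read by MTT assay, with a stated time of 24 h; a lower number here means a stronger inhibitor, a higher number a weaker inhibitor. Compound 1 `Cn1cnnc1SCC(=O)N/N=c1/scc(-c2ccc(Br)cc2)n1-c1ccccc1` gives 58.3 ug/mL in this assay. Compound 2 `Cn1cnnc1SCC(=O)N/N=c1/scc(-c2ccc(C#N)cc2)n1-c1ccccc1` gives 153 ug/mL in this assay. Compound 3 `Cc1nnc(SCC(=O)N/N=c2/scc(-c3ccc(C#N)cc3)n2-c2ccccc2)s1` reaches only a limit of the assay, < 3.9 ug/mL in this assay, so no number is known for it.

Compound 2 and compound 1 differ in one place: bromo in place of cyano on an aromatic carbon. This change made a 2.6-fold lower number from compound 2 to compound 1 (0.42 log units; beyond the scatter). Compound 2 and compound 3 differ in their cores: 5-methyl-1,3,4-thiadiazol-2-yl in place of 4-methyl-4H-1,2,4-triazol-3-yl on a sulfur. This change made an at least 39-fold lower number from compound 2 to compound 3 (1.59 log units; beyond the scatter), and the number at the end of that step is only a limit, (the limit of < 3.9 ug/mL in this assay, at which 1 of the 3 values shown sits).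

Compound 4 `Cc1nnc(SCC(=O)N/N=c2/scc(-c3ccc(Br)cc3)n2-c2ccccc2)s1` has not yet been measured in this assay. It differs from compound 3 in the same place and in the same way as compound 1 differs from compound 2: bromo in place of cyano on an aromatic carbon. The change is the same in both pairs, since the surroundings of the place are the same in each.

Because the same change gave a 2.6-fold lower number from compound 2 to compound 1 (0.42 log units; beyond the scatter), a modest lowering of the number is expected for a step that the limit leaves unreadable from compound 3 to compound 4. Compound 3 already sits at the limit (the limit of < 3.9 ug/mL in this assay, at which 1 of the 3 values shown sits), so the expected number for compound 4 lies at or beneath that limit. Compound 4 is therefore estimated at 2.5 ug/mL in this assay. The expected range for compound 4 runs from 0.8 ug/mL to 6 ug/mL, and it is quite likely that the assay would again report only a limit rather than a number.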

Compound 4, half-maximal inhibitory concentration: 55 ug/mL
Beside the measured number, compound 4's estimate is 22-fold (1.34 log units) below it; the whole stated range lies below it.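

In this assay, bromo in place of cyano gave an at least 14-fold higher number from compound 3 to compound 4 (1.14 log units; beyond the scatter), so the step seen on the core of compound 1 did not carry over to the core of compound 4 and the two steps point in opposite directions: the same change on two cores in this assay, a 2.6-fold lower number (0.42 log units; beyond the scatter) from compound 2 to compound 1 and an at least 14-fold higher number (1.14 log units; beyond the scatter) from compound 3 to compound 4, at least 37-fold (1.56 log units) apart, beyond the scatter of two such steps

Read the other way round, the exchange of the group on sulfur gave a 1.1-fold lower number from compound 1 to compound 4 (0.03 log units; within the scatter), which leaves the bromo pair level, while the same exchange in the cyano pair gave a far larger step: the same change on two cores in this assay, an at least 39-fold lower number (1.59 log units; beyond the scatter) from compound 2 to compound 3 and a 1.1-fold lower number (0.03 log units; within the scatter) from compound 1 to compound 4, at least 37-fold (1.56 log units) apart, beyond the scatter of two such steps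

Compound 3 stands only at a limit, so the gap between the steps is known as a bound and not as a number, and these four compounds show that the result of this change differs between the two cores without showing why: the limit of < 3.9 ug/mL in this assay, at which 1 of the 4 values shown sits.

On these data alone, whether an amine or a chloro group in place of cyano on that aromatic carbon would behave like bromo on each core remains open. Also open, as far as these compounds go, is whether a longer chain in place of the methyl group on either core would keep the same difference between the two cores.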